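A few compounds are considered here, and "the series" means these few. Any claim that something is new, unique, unknown or untested is made for them only; others in the source may bear on it.

Three compounds have been measured in a functional assay on MDA-MB-468 cells (Homo sapiens) for inhibition, read by sulforhodamine B assay, with a stated time of 48 h; a higher number here means a weaker inhibitor of growth, a lower number a stronger inhibitor of growth:

Compound 1 `O=C(Nc1cccc(-n2cc(-c3ccncc3)c(-c3ccc(Cl)c(O)c3)n2)c1)Nc1cccc(C(F)(F)F)c1` gives 980 nM.
Compound 2 `COc1cc(-c2nn(-c3cccc(NC(=O)c4cccc(C(F)(F)F)c4)c3)cc2-c2ccncc2)ccc1Cl` gives 1320 nM.
Compound 3 `COc1cc(-c2nn(-c3cccc(NC(=O)Nc4ccc(Cl)c(Cl)c4)c3)cc2-c2ccncc2)ccc1Cl` gives 567 nM.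

Compound 3 gives the lowest of the three numbers, but its gap to compound 1 is within the scatter of repeated measurements, so only compound 2 is clearly separated from it. Going by the values given here, the single step measured between neighbours, a 2.3-fold lower number from compound 2 to compound 3 (0.37 log units; beyond the scatter), concerns the link between the two aryl groups, not the aryl group itself.

Compound 4 `COc1cc(-c2nn(-c3cccc(NC(=O)Nc4cccc(C(F)(F)F)c4)c3)cc2-c2ccncc2)ccc1Cl` differs from compound 3 in one place: 3-(trifluoromethyl)phenyl in place of 3,4-dichlorophenyl on an amide-type nitrogen. Among the compounds with values here, no measured step exchanges these two aryl groups directly. Compound 1, however, carries the same 3-(trifluoromethyl)phenyl urea on a closely related core, and its number sits within the scatter of that of compound 3. For compound 4 a number close to compound 3 is therefore expected, with the step of a 1.4-fold higher number from compound 3 to compound 4 (0.15 log units; within the scatter) judged as none beyond the scatter. Compound 4 is estimated at 800 nM, within a range from 350 nM to 1800 nM.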

Compound 4, concentration for 50% growth inhibition: 598 nM
The estimate for compound 4 lay 1.3-fold (0.13 log units) above the measured number; the measured number falls inside the stated range.
By their numbers in this assay, from the lowest: compounds 3, 4, 1 and 2 (each within the scatter of the next, the first and the last beyond it).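

Swapping 3,4-dichlorophenyl for 3-(trifluoromethyl)phenyl on the amide-type nitrogen leaves this assay within the scatter (a 1.1-fold higher number from compound 3 to compound 4 (0.02 log units; within the scatter)), so these two aryl groups cannot be told apart here. Going by these compounds alone, compound 2 had so far been compared only with a compound differing in both the link and the aryl group; with the 3-(trifluoromethyl)phenyl kept, the added amino on the carbonyl carbon still goes with a lower number (a 2.2-fold lower number from compound 2 to compound 4 (0.34 log units; beyond the scatter)), a step beyond the scatter but modest. Methyl in place of hydrogen on the oxygen on the aromatic ring also stays within the scatter (a 1.6-fold lower number from compound 1 to compound 4 (0.21 log units; within the scatter)), and no measurement at hand explains these steps.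

The compounds shown leave open whether other groups on that nitrogen, such as an unsubstituted phenyl or a phenyl carrying a carboxylic acid or an amine, would fit equally well.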